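Working notes: 1-chloroethyl to chloromethyl in compound 3

The source may hold more compounds than are shown below. What is called first, only, known or untested is meant among the compounds shown, and "the series" means these compounds.

Measured in a functional assay on CCRF-CEM cells (Homo sapiens) for antiproliferative activity, read by trypan blue exclusion, with a stated time of 72 h; on this read-out lower numbers stand for stronger inhibition and higher numbers for weaker inhibition:
- compound 1 `Cc1ccc(C(=O)NC(N)=O)cc1NC(=O)C(C)Cl`: > 20000 nM
- compound 2 `CC(Cl)C(=O)Nc1cc(C(=O)NC(N)=O)ccc1Cl`: > 20000 nM

Both entries are limits of the assay, not numbers. For the measured compounds named here, compound 2 thus stands only at a limit, and compound 1 offers no number to set against it: the series so far reads (the limit of > 20000 nM in this assay, at which 2 of the 2 values shown sit).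

Compound 3 `NC(=O)NC(=O)c1ccc(Cl)c(NC(=O)CCl)c1` has not yet been measured. It carries hydrogen in place of methyl on a saturated chain carbon bound to a carbonyl carbon and a chlorine atom, which turns 1-chloroethyl into chloromethyl: hydrogen in place of methyl on a saturated chain carbon bound to a carbonyl carbon and a chlorine atom.

Going by the values given here, the only measured step is a step that the two limits leave unreadable from compound 1 to compound 2, which is chloro in place of methyl on an aromatic carbon. It is a different change at a different place, and it has no readable size. No measured step sizes the change at hand, so no step beyond the scatter is expected in this assay, and no direction can be given. The estimated step is a number no higher from compound 2 to compound 3 (the limit leaves the size open). Compound 3 may well report only a limit too. For compound 3 the expected value is 20000 nM, with an estimated range of 6000 nM to 40000 nM.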

Compound 3, half-maximal inhibitory concentration: 15900 nM
Beside the measured number, compound 3's estimate is 1.3-fold (0.10 log units) above it, within the range that was stated.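

In this assay, for the compounds shown here, hydrogen in place of methyl on a saturated chain carbon bound to a carbonyl carbon and a chlorine atom gives the first step with a readable floor: an at least 1.2-fold lower number from compound 2 to compound 3 (0.09 log units; that floor lies within the scatter). The step has a floor and no upper size, and that floor alone does not separate the two compounds, so the change from 1-chloroethyl to chloromethyl cannot yet be given a size or be called a real gain. Compound 3 is still the first compound in the series to report a number, while the other entries stay at a limit of the assay: the limit of > 20000 nM in this assay, at which 2 of the 3 values shown sit.

Open is whether the chloromethyl result carries over to the shared core with methyl in place of chloro on the aromatic carbon, as the compounds shown include no chloromethyl partner for compound 1. Also open, as far as these compounds go, is how this assay responds when the chlorine on this chain gives way to an amine or a hydroxyl group, or when the chain is replaced by a longer chain.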